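A few compounds are considered here, and "the series" means these few. Any claim that something is new, unique, unknown or untested is made for them only; others in the source may bear on it.

In an ADME assay on MDCK cells (Canis lupus familiaris) for cytotoxicity, read by MTT assay, with a stated time of 24 h (on this read-out lower numbers stand for higher toxicity in this test and higher numbers for lower toxicity in this test), compound 2 `O=S(=O)(NCc1csc2ccccc12)c1ccc(F)cc1` gives 98600 nM and compound 1 `Cc1cc(CNS(=O)(=O)c2ccc(C#N)cc2)c(C)o1` gives 105000 nM. For the measured compounds named here, these two numbers lie within the usual scatter of each other, so compound 2 stands level with the only other compound that has a number. For compound 3 `O=S(=O)(NCc1csc2ccccc12)c1ccccc1F` the record reads "not determined" (no result reported). Compound 4 `CC(=O)c1ccc(S(=O)(=O)NCc2csc3ccccc23)cc1` is compound 2 with acetyl in place of fluoro on an aromatic carbon, para to a large group: acetyl in place of fluoro on an aromatic carbon. Going by the values given here, with compound 2 at 98600 nM as the starting point and no measured pair showing such a change, no step beyond the scatter is expected in this assay, in either direction. For compound 4 the estimated value is 90000 nM, with an expected range from 40000 nM to 200000 nM. This estimate means an expected step of a 1.1-fold lower number from compound 2 to compound 4 (0.04 log units; within the scatter).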

Compound 4, half-maximal cytotoxic concentration: > 193000 nM
Compound 4 gave a limit, no number (the forecaster's own chance of this, stated with the estimate: 20%); middle value at least 2.1-fold (0.33 log units) from the limit.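

For the compounds shown here, this is the first pair in this assay that differs in one place, and swapping fluoro for acetyl on this aromatic carbon, para to a large group, gives an at least 1.9-fold higher number from compound 2 to compound 4 (0.29 log units; that floor lies within the scatter). So the larger acetyl group brings no lower number here, which means no sign of higher toxicity in this test. The result for compound 4 is a limit and not a number, so the true size of the step stays unknown: the limit of > 193000 nM in this assay, at which 1 of the 4 values shown sits.

The compounds shown leave open whether an amine or a carboxylic acid in this place would read the same. They also leave open whether acetyl would behave alike on the core of compound 1.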